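Bromo to nitro on the aryl ether of compound 2

The compounds below may be only part of what the source reports. "The series", "measured", "known", "first", "only" and "open" are said of these compounds alone.

Among the compounds with values here, compound 2 `Fc1ccc(NC(=S)N/N=C/c2ccc(Oc3ccc(Br)cc3)cc2)cc1` stands lowest of the two numbers so far in a physicochemical assay for lipophilicity, in phosphate buffer, measured as octanol-water partition, with a stated time of 24 h (on this read-out lower numbers stand for lower lipophilicity and higher numbers for higher lipophilicity), where compound 2 gives 5.88. The nearest neighbour is compound 1 `Cc1cc(Oc2ccc(/C=N/NC(=S)Nc3ccc(F)cc3)cc2)ccc1Cl`, which in this assay gives 6.07; the step of a number 0.19 log units lower from compound 1 to compound 2 (within the scatter) is within the scatter and exchanges 4-bromophenyl for 4-chloro-3-methylphenyl on an oxygen on an aromatic ring. Compound 3 `O=[N+]([O-])c1ccc(Oc2ccc(/C=N/NC(=S)Nc3ccc(F)cc3)cc2)cc1` is not yet measured. Its change from compound 2 is nitro in place of bromo on an aromatic carbon, on an aromatic carbon of a six-membered aromatic ring of carbon only, para to a large group; one bond further out it reads 4-bromophenyl to 4-nitrophenyl. Within the data shown here, no measured step exchanges a halogen for a nitro group, so the step between compound 1 and compound 2 bears on it only in showing that another substituent on that ring left the number within the scatter. The expected step from compound 2 to compound 3 in this assay is a number 0.98 log units lower from compound 2 to compound 3 (beyond the scatter), downward and beyond the scatter. Compound 3 is expected to give 4.9 in this assay, within 4.4 to 5.4.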

Compound 3, partition coefficient: 4.89
Compound 3: middle estimate off by 0.01 log units, on the high side; low and high end bracket the measured number.
By their numbers in this assay, from the lowest: compound 3; then compounds 2 and 1 (each within the scatter of the next).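

In this assay this position proves able to move the number well beyond the scatter: nitro in place of bromo on an aromatic carbon, para to a large group, gives a number 0.99 log units lower from compound 2 to compound 3 (beyond the scatter) and so contrasts with the earlier exchange on the same ring, a number 0.19 log units lower from compound 1 to compound 2 (within the scatter) in this series. Set against the 4-chloro-3-methylphenyl group, 4-nitrophenyl gives a number 1.18 log units lower from compound 1 to compound 3 (beyond the scatter) as the largest step so far, which leaves compound 3 apart from the two halogen-bearing compounds. Nothing measured here accounts for the size of these steps.

As far as these compounds go, whether an amine or a carboxylic acid on the same aromatic carbon would lie near compound 3 or further from compound 2 remains open. A single nitro compound also leaves open whether this step would hold with another group elsewhere on the shared core.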